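The source may report more compounds than this note shows. Statements on the series, on what has been measured and on what is new or still open speak of the compounds shown alone.

In an in vivo ADME assay on the whole organism for metabolic stability, with Rattus norvegicus as the target, at a dose of 10 mg/kg by the intravenous route (a higher number here means that the compound lasts longer, a lower number that the compound disappears faster), compound 2 `C[C@@](CCc1ccc(-c2ccc(O)cc2)cc1)(C(=O)NO)S(C)(=O)=O` stands highest of the two numbers measured, giving 1.4 h, while compound 1 `C[C@@](CCc1ccc(-c2ccc(C#N)cc2)cc1)(C(=O)NO)S(C)(=O)=O` gives 0.6 h. Going by the values given here, the one step measured so far, a 2.3-fold higher number from compound 1 to compound 2 (0.37 log units; beyond the scatter), comes from a change at the far aromatic ring: hydroxy in place of cyano on an aromatic carbon. Compound 3 `C[C@@](CCc1ccc(-c2ccc(O)cc2)cc1)(C(=O)O)S(C)(=O)=O` differs from compound 2 elsewhere: hydroxy in place of hydroxyamino on a carbonyl carbon. Among the compounds with values here, no measured step touches the carbonyl carbon, so the step from compound 1 to compound 2 does not bear on this change and nothing in the data points to a direction. With only the half-life of compound 2 as an anchor, a change of either sign within the scatter is as likely as none, and the estimate is therefore wide. Compound 3 is expected to give about 1.6 h in this assay, between 0.6 h and 4 h, a step of a 1.1-fold higher number from compound 2 to compound 3 (0.06 log units; within the scatter) that is an estimate rather than a measurement.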

Compound 3, half-life: 0.7 h
The estimate for compound 3 lay 2.3-fold (0.36 log units) above the measured number, within the range that was stated.
By their numbers in this assay, from the lowest: compounds 1, 3 and 2 (each within the scatter of the next, the first and the last beyond it).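

Going by these compounds alone, this is the first measured step at the carbonyl carbon, and in this assay the change from hydroxycarbamoyl to carboxy gives a 2.0-fold lower number from compound 2 to compound 3 (0.30 log units; within the scatter). Because that step lies within the scatter, the half-life does not separate the two groups at this position, whereas the earlier step at the other site of change lay beyond it. No experimental evidence shown here accounts for the result.

The compounds shown leave open whether a primary amide or a methyl ester on the same carbonyl carbon would give a half-life clearly apart from those of hydroxycarbamoyl and carboxy. They also leave open whether the carboxy group would behave in the same way with a nitrile in place of the hydroxy on the aromatic carbon.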